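Replacing nitro with amino in compound 2

The source may hold more compounds than are shown below. What is called first, only, known or untested is meant among the compounds shown, and "the series" means these compounds.

Measured in a functional assay on HT-29 cells (Homo sapiens) for antiproliferative activity, read by MTT assay, with a stated time of 72 h (a higher number here means a weaker inhibitor, a lower number a stronger inhibitor), so far
Compound 1 `COc1ccc(NC(=O)c2cc(OC)c(OC)c(OC)c2)cc1[N+](=O)[O-]` gives 9700 nM
Compound 2 `COc1ccc(OC(=O)c2cc(OC)c(OC)c(OC)c2)cc1[N+](=O)[O-]` gives > 100000 nM as a limit of the assay

Compound 2 has no numerical value, and its reading of > 100000 nM is only a limit of the assay. Compound 3 `COc1ccc(OC(=O)c2cc(OC)c(OC)c(OC)c2)cc1N` is compound 2 with amino in place of nitro on an aromatic carbon, ortho to a methoxy group (amino in place of nitro on an aromatic carbon). For the measured compounds named here, no measured step shows what this change does in this assay, so the expectation is loose. A moderate shift towards stronger inhibition, beyond the scatter, is expected, although compound 3 could also remain at the limit. The nearest measured number comes from compound 1 (9700 nM), and the estimate is anchored there. The estimated change is an at least 6.6-fold lower number from compound 2 to compound 3 (0.82 log units; beyond the scatter) in this expectation. For compound 3 the estimated value is 15000 nM with an expected range from 1500 nM to 100000 nM in all.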

Compound 3, half-maximal inhibitory concentration: > 100000 nM
Compound 3 gave a limit, no number (the forecaster's own chance of this, stated with the estimate: 30%); middle value at least 6.6-fold (0.82 log units) from the limit.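

Compound 2 and compound 3 both end at a limit of the assay, so no step can be read between them, because both sit at the same ceiling: the limit of > 100000 nM in this assay, at which 2 of the 3 values shown sit.

The compounds shown leave open whether amino in place of nitro on an aromatic carbon changes antiproliferative activity at all.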